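The source may hold more compounds than are shown below. What is called first, only, known or untested is meant among the compounds shown, and "the series" means these compounds.

Going by the values given here, compound 1 `Nc1nc(NCc2ccccc2)nc(-c2ccccc2CO)n1` is the more potent of the two compounds measured so far. In a functional assay on cells for positive allosteric modulation of G-protein coupled receptor 68 (Homo sapiens), read by a luciferase reporter and cAMP accumulation, with a stated time of 30 min, at pH 6.8 and pH 8.3, in the presence of a further agent that is not named here (on this read-out lower numbers stand for lower potency and higher numbers for higher potency (the scale is a negative logarithm)), compound 1 gives 4.35, while compound 2 `NCc1ccccc1-c1nc(N)nc(NCc2ccccc2)n1`, in which the hydroxymethyl group is replaced by an aminomethyl group, gives 3.86 in the same assay. That single change, amino in place of hydroxy on a saturated chain carbon bound to an aromatic carbon, produced a number 0.49 log units lower from compound 1 to compound 2 (beyond the scatter).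

Compound 3 `Nc1nc(NCc2ccccc2)nc(-c2ccc(F)cc2CO)n1` keeps the hydroxymethyl group of compound 1 and differs from it only by fluoro in place of hydrogen on an aromatic carbon, placed meta to the hydroxymethyl group and para to a large group. Among the compounds with values here, no measured step involves a fluoro substituent on this ring, so the one measured step, which concerns a different position and group, does not bear on this change. The expected result is therefore a step of a number 0.05 log units higher from compound 1 to compound 3 (within the scatter), not beyond the scatter. Compound 3 is estimated at 4.4, within a range of 3.9 to 4.9.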

Compound 3, negative logarithm of the antagonist equilibrium constant: 4.58
Compound 3: the middle estimate sits 0.18 log units below what was measured, within the range that was stated.
By their numbers in this assay, from the lowest: compound 2; then compounds 1 and 3 (each within the scatter of the next).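

In this assay, fluoro in place of hydrogen on this aromatic carbon, meta to the hydroxymethyl group and para to a large group, gives a number 0.23 log units higher from compound 1 to compound 3 (within the scatter). The earlier step changed the hydroxymethyl group itself and lay beyond the scatter, whereas this one shows that a single fluorine can sit on this ring carbon of compound 1 with no change that can be told apart from repeat-measurement noise. Nothing measured here accounts for the result.

A chloro, methyl or methoxy group on the same carbon could show whether something larger than fluoro also leaves the number within the scatter. Fluoro on the other ring carbons, and fluoro paired with the aminomethyl group, also remain open.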